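A few compounds are considered here, and "the series" means these few. Any claim that something is new, unique, unknown or untested is made for them only; others in the source may bear on it.

Compound 3 `O=C(Nc1ccc(Cl)cc1)c1ccc2cccnc2c1O` gives 380 nM in a functional assay on NALM-6 cells (Homo sapiens) for cytotoxicity, read by luminescence and CellTiter-Glo, with a stated time of 3 days (on this read-out higher numbers stand for weaker inhibition and lower numbers for stronger inhibition), the second highest of the three numbers to hand. Its nearest neighbour is compound 1 `N#Cc1cc(Cl)ccc1NC(=O)c1ccc2cccnc2c1O` at 280 nM; the step of a 1.4-fold higher number from compound 1 to compound 3 (0.13 log units; within the scatter) is within the scatter. Compound 2 `O=C(Nc1ccc(OC(F)(F)F)cc1)c1cc(F)ccc1O`, built on a different core, gives 1210 nM, a higher number than compound 3. Compound 4 `O=C(Nc1ccc(C(F)(F)F)cc1)c1ccc2cccnc2c1O` is the next member: trifluoromethyl in place of chloro on an aromatic carbon. Within the data shown here, no measured step covers trifluoromethyl in place of chloro on an aromatic carbon; the only step available, from compound 1 to compound 3, is within the scatter. The step of a 1.1-fold higher number from compound 3 to compound 4 (0.02 log units; within the scatter) is therefore expected to stay within the scatter, in no clear direction. Compound 4 is estimated at 400 nM, within a range of 150 nM to 1100 nM.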

Compound 4, half-maximal inhibitory concentration: 380 nM
Compound 4: middle estimate off by 1.1-fold (0.02 log units), on the high side; the measured number falls inside the stated range.
By their numbers in this assay, from the lowest: compounds 1, 3 and 4 (each within the scatter of the next); then compound 2.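

In this assay trifluoromethyl in place of chloro, on an aromatic carbon para to a large group, gives no change at the digits printed from compound 3 to compound 4 (within the scatter) on the shared core. The earlier step of a 1.4-fold higher number from compound 1 to compound 3 (0.13 log units; within the scatter) concerned cyano and said nothing about this position. No available evidence bears on this result.

As far as these compounds go, whether hydrogen, an amine or a carboxylic acid at this position would also stay within the scatter remains open. From the compounds shown here alone, compound 2 differs from compound 3 in more than one place, so what its core contributes also remains open.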